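Swapping the Aryl Ketone for an Ethyl Ester

This account rests on a few compounds, and the source may have more. Where it says the series, first, only, none or still open, it means among the compounds named here.

Compound 1, `COc1ccccc1C(=O)c1sc2nc(-c3cccs3)ccc2c1N`, gives 0.059 ug/mL in a functional assay on WI-38 VA13 cells (Homo sapiens) for cytotoxicity; on this read-out higher numbers stand for an effect only at larger amounts of compound and lower numbers for an effect already at smaller amounts. Compound 2, `COc1ccc(C(=O)c2sc3nc(-c4cccs4)ccc3c2N)cc1`, gives 0.77 ug/mL.

Compound 2 thus carries the highest of the two numbers, with compound 1 standing below it by a 13-fold higher number from compound 1 to compound 2 (1.12 log units; beyond the scatter). Compound 3, `CCOC(=O)c1sc2nc(-c3cccs3)ccc2c1N`, differs from compound 2 in one place: ethoxy in place of 4-methoxyphenyl on a carbonyl carbon. Among the measured compounds shown here, no measured step covers the loss of the whole aromatic group at the carbonyl carbon; the only measured step, a 13-fold higher number from compound 1 to compound 2 (1.12 log units; beyond the scatter), shows that changing just the methoxy position on that ring already moved the number far beyond the scatter. Compound 3 is therefore expected to move again, with a step of a 3.9-fold higher number from compound 2 to compound 3 (0.59 log units; beyond the scatter), and its estimated value is 3 ug/mL, ranging from 0.5 ug/mL to 20 ug/mL.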

Compound 3, half-maximal effective concentration: > 4 ug/mL
Compound 3 was reported as a limit (the forecaster's own chance of this, stated with the estimate: 15%); middle value at least 1.3-fold (0.12 log units) from the limit.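

Putting ethoxy on the carbonyl carbon removes the aromatic ring altogether and gives an at least 5.1-fold higher number from compound 2 to compound 3 (0.71 log units; beyond the scatter), and from the other methoxy isomer it gives an at least 67-fold higher number from compound 1 to compound 3 (1.83 log units; beyond the scatter). Among these three compounds, then, an effect at smaller amounts in this assay goes with an aromatic ring at this place, whichever position its methoxy takes. The figure for compound 3 is a limit, not a number: the limit of > 4 ug/mL in this assay, at which 1 of the 3 values shown sits.

As far as these compounds go, the true number for compound 3, and so the full size of both steps, stays open. Also open, from the compounds shown here alone, is whether any aromatic ring serves here, or whether the methoxy matters: a plain phenyl, a pyridine or an amine on the carbonyl carbon would help to tell.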